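A few compounds are considered here, and "the series" means these few. Any claim that something is new, unique, unknown or untested is made for them only; others in the source may bear on it.

Measured so far in a functional assay on SGC-7901 cells (Homo sapiens) for antiproliferative activity, read by MTT assay, with a stated time of 72 h; on this read-out lower numbers stand for stronger inhibition and higher numbers for weaker inhibition
compound 1 `COc1ccc(-c2ccc3ncn(-c4cc(OC)c(OC)c(OC)c4)c3c2)cc1O` gives 44 nM
compound 2 `COc1cc(-n2cnc3ccc(-c4cc(F)ccc4F)cc32)cc(OC)c1OC` gives 6590 nM
compound 3 `COc1cc(-n2cnc3ccc(-c4ccc([N+](=O)[O-])cc4)cc32)cc(OC)c1OC` gives 79 nM

Compound 3 sits with compound 1, their two values within the scatter of each other, while compound 2 lies far up the scale from both. Next comes compound 4 `COc1cc(-n2cnc3ccc(-c4ccccc4)cc32)cc(OC)c1OC` with hydrogen in place of nitro on an aromatic carbon so that 4-nitrophenyl becomes phenyl. For the measured compounds named here, no measured step removes a substituent outright, so the evidence is indirect. Three steps exchange the aryl group: a 1.8-fold higher number from compound 1 to compound 3 (0.25 log units; within the scatter) is small, whereas a 150-fold higher number from compound 1 to compound 2 (2.18 log units; beyond the scatter) and an 83-fold lower number from compound 2 to compound 3 (1.92 log units; beyond the scatter) are both large. Exchanging this group can therefore leave the number unchanged within the scatter or move it strongly, and three compounds show no trend. Going by the values given here, compound 4 matches none of the measured aryl groups, so a moderate loss is the working expectation, well short of the large steps but with wide uncertainty. In this assay the expected outcome is a 4.4-fold higher number from compound 3 to compound 4 (0.65 log units; beyond the scatter) as a shift toward weaker inhibition. For compound 4 the estimated value is 350 nM with an expected range from 70 nM to 2500 nM on this measure.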

Compound 4, half-maximal inhibitory concentration: 290 nM
Estimate against measurement, compound 4: 1.2-fold (0.08 log units) above; the measured number falls inside the stated range.
By their numbers in this assay, from the lowest: compounds 1 and 3 (each within the scatter of the next); then compound 4; then compound 2.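

In this assay, the nitro group at this place, para to a large group, is now read against hydrogen directly (a 3.7-fold higher number from compound 3 to compound 4 (0.56 log units; beyond the scatter)), so 4-nitrophenyl holds a modest advantage over plain phenyl. Phenyl also gives a reference point for the other aryl groups: the number lies on the weaker side of 3-hydroxy-4-methoxyphenyl (a 6.6-fold higher number from compound 1 to compound 4 (0.82 log units; beyond the scatter)) and far on the stronger side of 2,5-difluorophenyl (a 23-fold lower number from compound 2 to compound 4 (1.36 log units; beyond the scatter)), so among these four compounds substitution on this ring moves the number in both directions, with compound 2 going against any general benefit from substituents. Nothing in the data gives a measured basis for these shifts.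

The compounds shown leave open whether the advantage of compound 3 is specific to nitro or would also appear with another group at the same place, such as a nitrile, an amine or a carboxylic acid. They also do not separate the two fluorines of compound 2, so a single fluorine at either place, and the separate contributions of the hydroxy and methoxy groups of compound 1, remain unresolved.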